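Weak Inhibitors in HeLa Cells: One Replacement Considered

A few compounds are considered here, and "the series" means these few. Any claim that something is new, unique, unknown or untested is made for them only; others in the source may bear on it.

Compound 1 `CCOC(=O)C1=Cc2ccccc2OC1(OCc1cn(CC(=O)Nc2ccc(C)cc2)nn1)C(F)(F)F` is a weak inhibitor in a functional assay on HeLa cells (Homo sapiens) for inhibition, read by MTT assay, with a stated time of 24 h; a higher number here means a weaker inhibitor, a lower number a stronger inhibitor: compound 1 gives 67400 nM. Within the data shown here, it is the only compound in the set with a number of its own; the other value is a limit. Compound 2 `O=C(O)C1=Cc2ccccc2OC1(OCc1cc(-c2cccc(C(F)(F)F)c2)no1)C(F)(F)F` reaches only a limit in this assay, at which compound 2 gives > 150000 nM, and the limit of > 150000 nM in this assay, at which 1 of the 2 values shown sits, accounts for one of the two values seen. Among the measured compounds shown here, no pair of measured compounds differs in a single place, so no measured step is available to judge the size of a change.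

Compound 3 `CCOC(=O)C1=Cc2ccccc2OC1(OCc1cn(-c2cccc(OC)c2)nn1)C(F)(F)F` has not yet been measured. It differs from compound 1 in one place: 3-methoxyphenyl in place of ((4-methylphenyl)carbamoyl)methyl on an aromatic nitrogen. The shared core of compound 1 and compound 3 stays the same.

For the measured compounds named here, with no measured step of this kind to lean on, the step from compound 1 to compound 3 is expected to stay within the scatter, and a 1.1-fold lower number from compound 1 to compound 3 (0.05 log units; within the scatter) is the estimate. Since compound 1 gives 67400 nM, compound 3 is expected to give about 60000 nM, between 20000 nM and 180000 nM.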

Compound 3, half-maximal inhibitory concentration: > 150000 nM
Compound 3: only a limit was reported (the forecaster's own chance of this, stated with the estimate: 30%); at least 2.5-fold (0.39 log units) between middle value and limit.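

Compound 3 gives the set its first measured step, and in this assay its value is a limit: compound 3 gives > 150000 nM. Even so, placing 3-methoxyphenyl in place of ((4-methylphenyl)carbamoyl)methyl on an aromatic nitrogen gives an at least 2.2-fold higher number from compound 1 to compound 3 (0.34 log units; beyond the scatter), which shows that the group at this position can move the reading in the weaker direction. The step has a lower bound only, and its full size stays unknown: the limit of > 150000 nM in this assay, at which 2 of the 3 values shown sit.

The change alters several things at once, since the carbamoyl unit with the amide hydrogen leaves and a methoxy-bearing ring enters, so the compounds shown do not tell which of these parts accounts for the step. From the compounds shown here alone, a plain phenyl or a carboxylic acid on a longer chain at this nitrogen would bear on that question, and whether any group here can bring the number clearly below that of compound 1 remains open.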